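Meta Trifluoromethyl on the Pyrazoline Aryl Ring

The source may report more compounds than this note shows. Statements on the series, on what has been measured and on what is new or still open speak of the compounds shown alone.

Compound 1 `CC(C)(C)C1=NN(c2ccc(F)cc2)C(c2ccc(O)cc2)C1` gives 9400 nM in an assay on isolated protein for inhibition of protein kinase C zeta type (Homo sapiens), with a stated time of 4 min; on this read-out higher numbers stand for weaker inhibition and lower numbers for stronger inhibition. Compound 2 `CC(C)(C)C1=NN(c2ccc(C(F)(F)F)cc2)C(c2ccc(O)cc2)C1` carries trifluoromethyl in place of fluoro on an aromatic carbon and gives 8800 nM, so that a 1.1-fold lower number from compound 1 to compound 2 (0.03 log units; within the scatter). Compound 3 `CC(C)(C)C1=NN(c2cccc(F)c2)C(c2ccc(O)cc2)C1` has the same atoms as compound 1 joined differently, (3-fluorophenyl in place of 4-fluorophenyl on an amine nitrogen in a ring). In this assay compound 3 gives 2200 nM; here a 4.3-fold lower number from compound 1 to compound 3 (0.63 log units; beyond the scatter), leaving compound 3 with the lowest number of the three. Compound 4 `CC(C)(C)C1=NN(c2cccc(C(F)(F)F)c2)C(c2ccc(O)cc2)C1` has not been measured in this assay . It differs from compound 3 by trifluoromethyl in place of fluoro on an aromatic carbon, the same kind of change as that from compound 1 to compound 2, though there the group sat para to a large group and here it sits meta to a large group. For compound 4 the expected step is a 1.0-fold lower number from compound 3 to compound 4 (0.02 log units; within the scatter), chosen because a 1.1-fold lower number from compound 1 to compound 2 (0.03 log units; within the scatter) lies within the scatter. Compound 4 is thus expected to give 2100 nM, between 900 nM and 5000 nM.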

Compound 4, half-maximal inhibitory concentration: 2700 nM
Compound 4: middle estimate off by 1.3-fold (0.11 log units), on the low side; low and high end bracket the measured number.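

In this assay, trifluoromethyl in place of fluoro on an aromatic carbon gives a 1.2-fold higher number from compound 3 to compound 4 (0.09 log units; within the scatter), and this agrees with the same change made on the core of compound 1: the same change on two cores in this assay, a 1.1-fold lower number (0.03 log units; within the scatter) from compound 1 to compound 2 and a 1.2-fold higher number (0.09 log units; within the scatter) from compound 3 to compound 4, 1.3-fold (0.12 log units) apart, within the scatter of two such steps In these two pairs, then, the change carries from one core to the other, and on neither does it move the number beyond the scatter. This rests on just two pairs, so it does not show that the change would stay as silent on any other core, nor does it explain why the number holds.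

The compounds shown leave open whether a different group on the same carbon, such as methoxy, a nitrile or an amine, would shift the number. They also leave open whether a carboxylic acid there would do so.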